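The source may hold more compounds than are shown below. What is called first, only, known or untested is meant among the compounds shown, and "the series" means these compounds.

Working notes on the series in a functional assay on PC-3 cells (Homo sapiens) (a higher number here means a weaker inhibitor of growth, a lower number a stronger inhibitor of growth), all sharing one core. Compound 1 `N#Cc1ccc(/C=C/S(=O)(=O)Cc2ccc(Nc3ncnc4ccccc34)cc2)cc1` reads > 100000 nM, which is a limit of the assay and not a number. Compound 2 `O=S(=O)(/C=C/c1ccc(Cl)c(Cl)c1)Cc1ccc(Nc2ncnc3ccccc23)cc1` gives 35000 nM. Compound 3 `O=S(=O)(/C=C/c1ccc(Cl)cc1Cl)Cc1ccc(Nc2ncnc3ccccc23)cc1` gives 19000 nM. The gap between these two lies within the scatter: a 1.8-fold lower number from compound 2 to compound 3 (0.27 log units; within the scatter). Compound 3 therefore stands level with compound 2 and clearly apart from the limit: an at least 5.2-fold lower number from compound 1 to compound 3 (0.72 log units; beyond the scatter).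

Next is compound 4 `O=S(=O)(/C=C/c1ccc(F)cc1Cl)Cc1ccc(Nc2ncnc3ccccc23)cc1`, with the change (fluoro in place of chloro on an aromatic carbon). This puts fluoro in place of chloro on an aromatic carbon, para to a large group and meta to a chloro group. Within the data shown here, no measured step makes this exact swap. The nearest evidence is an at least 2.8-fold lower number from compound 1 to compound 2 (0.45 log units; beyond the scatter), alongside the two steps above. Replacing the whole substituted phenyl group can therefore move the number beyond the scatter, while relocating one chloro, as in a 1.8-fold lower number from compound 2 to compound 3 (0.27 log units; within the scatter), did not.

A single halogen swap is expected to give a small change in this assay, if any, leaning towards a higher number. The expected step is a 1.5-fold higher number from compound 3 to compound 4 (0.17 log units; within the scatter). For compound 4 the estimate is 28000 nM, with an expected range from 11000 nM to 70000 nM.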

Compound 4, concentration for 50% growth inhibition: 100000 nM
For compound 4 the middle estimate is 3.6-fold (0.55 log units) below the measured one, and the stated range ends below it.
By their numbers in this assay, from the lowest: compounds 3 and 2 (each within the scatter of the next); then compound 4.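

In this assay, among these compounds, fluoro in place of chloro on the aromatic carbon para to a large group is a real change, unlike the relocation of one chloro among the earlier compounds: a 5.3-fold higher number from compound 3 to compound 4 (0.72 log units; beyond the scatter). The 2-chloro-4-fluorophenyl group also stands apart from the 3,4-dichlorophenyl group: a 2.9-fold higher number from compound 2 to compound 4 (0.46 log units; beyond the scatter). The remaining step cannot be read for size: a number no higher from compound 1 to compound 4 (the limit leaves the size open). Compound 1 carries a limit and not a number: the limit of > 100000 nM in this assay, at which 1 of the 4 values shown sits.

Going by these compounds, with a single pair for this swap, no halogen trend can be claimed, and whether the same swap would move the number in the same way in the 3,4-dichlorophenyl setting stays open. Also open, on these data alone, is how a methyl, a methoxy or an amine would read at this position, with the chloro group meta to it kept in place.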